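Methyl for chloro at the para position of a shared core

The source may report more compounds than this note shows. Statements on the series, on what has been measured and on what is new or still open speak of the compounds shown alone.

Among the measured compounds shown here, compound 2 `CS(=O)(=O)c1ccc(-c2cnc3[nH]cc(-c4nnc(-c5ccc(Cl)cc5)o4)c(=O)c3c2)cc1` stands at the lower end of the two numbers measured so far. In a functional assay on HeLa cells (Homo sapiens) for inhibition, read by MTT assay, with a stated time of 24 h, tested at 10 uM (a higher number here means more inhibition of growth at the concentration tested, a lower number less inhibition of growth), compound 2 gives 1.64%, and its nearest neighbour, compound 1 `CS(=O)(=O)c1ccc(-c2cnc3[nH]cc(-c4nnc(-c5ccc(F)cc5)o4)c(=O)c3c2)cc1`, gives 15.7% in the same assay. For the measured compounds named here, the one measured step between them, a number 14.1 percentage points lower from compound 1 to compound 2 (beyond the scatter), arises from a chloro in place of a fluoro on an aromatic carbon.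

Compound 3 `Cc1ccc(-c2nnc(-c3c[nH]c4ncc(-c5ccc(S(C)(=O)=O)cc5)cc4c3=O)o2)cc1` is not yet measured. The change from compound 2 is methyl in place of chloro on an aromatic carbon, that is, 4-chlorophenyl becomes 4-methylphenyl at a position para to a large group. Going by the values given here, no measured step exchanges a halogen for a methyl, so the only related step is the one from compound 1 to compound 2, which was of modest size and moved the number downward when chloro replaced fluoro. Because that step, a number 14.1 percentage points lower from compound 1 to compound 2 (beyond the scatter), left compound 2 already near the bottom of the scale, compound 3 is expected to stay in the same region, with a step of a number 4.4 percentage points higher from compound 2 to compound 3 (within the scatter) that is estimated to lie within the scatter. The estimate for compound 3 is 6%, with a range from -5% to 20%.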

Compound 3, percent growth inhibition at one concentration: 18.5%
For compound 3 the middle estimate is 12.5 percentage points below the measured one; the range from low to high includes it.
By their numbers in this assay, from the lowest: compound 2; then compounds 1 and 3 (each within the scatter of the next).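

In this assay, the place on the aromatic ring para to a large group responds to the exchange of one single heavy atom for another: methyl in place of chloro gives a number 16.9 percentage points higher from compound 2 to compound 3 (beyond the scatter), so the low number of compound 2 goes with chloro and not with the shared core alone. Methyl in place of fluoro gives a number 2.8 percentage points higher from compound 1 to compound 3 (within the scatter), which means that among these three compounds chloro is the one that stands apart, while fluoro and methyl cannot be told apart at this place. Nothing available here bears on why chloro alone gives the lower number.

The compounds shown leave open how a methoxy group, an amine, a carboxylic acid or a longer chain such as ethyl would read at this place, and so whether chloro remains the exception or is one of several groups with a low number. They also leave open whether the same order among fluoro, chloro and methyl would hold on a core without the methylsulfonylphenyl group.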